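This account rests on a few compounds, and the source may have more. Where it says the series, first, only, none or still open, it means among the compounds named here.

Compound 3 `COc1ccc(C2N=C(SCc3cccc(Cl)c3)NC(C)=C2C(=O)Nc2ccc(Br)cc2)cc1` gives 33.8% in a functional assay on the whole organism (artery, strain albino) with Rattus norvegicus as the target, with a stated time of 240 min, at a dose of 10 mg/kg by the oral route (a lower number here means less inhibition, a higher number more inhibition at the dose given (going by the name of the read-out)), the highest of the three numbers recorded. Compound 1 `CC1=C(C(=O)Nc2ccc(Br)cc2)C(c2ccc(Cl)cc2Cl)N=C(SCc2ccc(Cl)cc2)N1` gives 32.3% in this assay, which lies within the scatter of compound 3, while compound 2 `COc1ccc(C2N=C(SCc3ccccc3)NC(C)=C2C(=O)Nc2ccc(Br)cc2)cc1` gives 13.3% in this assay and sits beyond the scatter below compound 3.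

Compound 4 `COc1ccc(C2N=C(SCc3ccc(Cl)cc3)NC(C)=C2C(=O)Nc2ccc(Br)cc2)cc1` has not been measured in this assay. It differs from compound 3 in one place: 4-chlorophenyl in place of 3-chlorophenyl on a saturated chain carbon bound to a sulfur.

For the measured compounds named here, only one measured step touches the same part of the molecule. The step of a number 20.5 percentage points higher from compound 2 to compound 3 (beyond the scatter) shows that a chlorine on that aromatic ring, in its original position, raised the read-out by a modest amount. Going by the values given here, nothing among the measured compounds shows how shifting the chlorine within the ring changes the read-out. Compound 1, which carries the same 4-chlorobenzyl group on sulfur but a different aryl group on the saturated carbon, gives a number within the scatter of compound 3, so that group is at least compatible with a read-out in this range.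

Compound 4 is therefore expected to show a number 2.8 percentage points lower from compound 3 to compound 4 (within the scatter), a step no larger than the scatter. The expected value for compound 4 is 31%, estimated within the range from 17% to 45%.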

Compound 4, a percentage reported as inhibition, in the whole organism at one dose (the size of the read-out at that dose, not a potency): 29.2%
Compound 4: the middle estimate sits 1.8 percentage points above what was measured; low and high end bracket the measured number.
By their numbers in this assay, from the lowest: compound 2; then compounds 4, 1 and 3 (each within the scatter of the next).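

In this assay, the change from 3-chlorophenyl to 4-chlorophenyl on a saturated chain carbon bound to a sulfur gives (a number 4.6 percentage points lower from compound 3 to compound 4 (within the scatter)), so this read-out does not separate the two chlorine placements at this position. The rise on adding chlorine to the unsubstituted ring of compound 2 is now seen for both placements, as (a number 20.5 percentage points higher from compound 2 to compound 3 (beyond the scatter)) and (a number 15.9 percentage points higher from compound 2 to compound 4 (beyond the scatter)), and each of these steps lies beyond the scatter. With the 4-chlorobenzyl group held constant, 4-methoxyphenyl in place of 2,4-dichlorophenyl on a saturated ring carbon gives (a number 3.1 percentage points lower from compound 1 to compound 4 (within the scatter)), so that exchange on the core also leaves the read-out within the scatter.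

Nothing available explains why chlorine at either placement raises the number over compound 2, or why the two placements cannot be told apart. The compounds shown also leave open whether a fluorine, a methyl group or a methoxy group on that ring would match chlorine, and what a longer chain between the sulfur and the ring would do to the read-out.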